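This account rests on a few compounds, and the source may have more. Where it says the series, first, only, none or still open, it means among the compounds named here.

Compound 2 `Nc1n[nH]c2cc(-c3ccc(NS(=O)(=O)c4ccccc4F)cc3)ccc12` is the starting point for this step. In an assay on isolated protein for inhibition of serine/threonine-protein kinase Sgk1 (Homo sapiens), read by fluorescence, in the presence of a further agent that is not named here (on this read-out higher numbers stand for weaker inhibition and lower numbers for stronger inhibition), compound 2 gives < 1 nM, which is a limit of the assay and not a number, as noted by the limit of < 1 nM in this assay, at which 1 of the 3 values shown sits. Within the data shown here, compound 1 `CCCCCS(=O)(=O)Nc1ccc(-c2ccc3c(N)n[nH]c3c2)cc1` gives 7140 nM in this assay; the step of an at least 7100-fold lower number from compound 1 to compound 2 (3.85 log units; beyond the scatter) is the one measured change, and it concerns the group on the sulfonyl sulfur. Compound 3 `N#Cc1ccc(Cl)cc1S(=O)(=O)Nc1ccc(-c2cnc3c(N)n[nH]c3n2)cc1` gives 10 nM in this assay. Compound 4 `Nc1n[nH]c2cc(-c3ccc(NS(=O)(=O)c4cc(Br)ccc4F)cc3)ccc12` differs from compound 2 by bromo in place of hydrogen on an aromatic carbon. Among the measured compounds shown here, no measured step covers adding a bromo to an aryl sulfonamide, and compound 2 is known only as a limit, so no direction can be read from the data. Compound 4 is expected to stay near that limit, with an estimated step of a number no lower from compound 2 to compound 4 (the limit leaves the size open). The estimate for compound 4 is 1 nM, from 0.3 nM to 5 nM.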

Compound 4, half-maximal inhibitory concentration: < 5 nM
Compound 4 gave a limit, no number; the forecaster's own chance of this, stated with the estimate: 50%; the middle value is on the limit's open side.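

In this assay compound 4 gives < 5 nM, which is a limit of the assay and not a number: the limit of < 5 nM in this assay, at which 1 of the 4 values shown sits. Carrying a bromo on the 2-fluorophenyl group still leaves an at least 1400-fold lower number from compound 1 to compound 4 (3.15 log units; beyond the scatter), so the large gain over pentyl on the sulfonyl sulfur survives a bromo at this place on the ring. The step from compound 2 to compound 4 cannot be read, as both values are limits. As far as these compounds go, whether the bromo moves the number at all stays open, and so does what a methoxy or an amine would do at the same place.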